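The source may report more compounds than this note shows. Statements on the series, on what has been measured and on what is new or still open speak of the compounds shown alone.

Measured so far in a functional assay on MGC-803 cells (Homo sapiens) for inhibition, read by MTT assay, with a stated time of 72 h; a higher number here means a weaker inhibitor, a lower number a stronger inhibitor:
compound 1, `O=C(CSc1nc(Nc2ccccc2)c2ccccc2n1)Nc1cccc(Cl)c1`, gives 14300 nM
compound 2, `O=C(CSc1nc(Nc2ccccc2)c2ccccc2n1)Nc1cccc(Br)c1`, gives 9620 nM
compound 3, `CCc1cccc(NC(=O)CSc2nc(Nc3ccccc3)c3ccccc3n2)c1`, gives 15800 nM

Compound 3 carries the highest number of the three, yet both gaps to the others stay within the scatter: a 1.1-fold higher number from compound 1 to compound 3 (0.04 log units; within the scatter) and a 1.6-fold higher number from compound 2 to compound 3 (0.22 log units; within the scatter). Compound 4, `O=C(CSc1nc(Nc2ccccc2)c2ccccc2n1)Nc1ccc(Cl)cc1`, differs from compound 3 by 4-chlorophenyl in place of 3-ethylphenyl on an amide-type nitrogen. For the measured compounds named here, the ethyl-against-chloro part of this change has a direct counterpart in a 1.1-fold higher number from compound 1 to compound 3 (0.04 log units; within the scatter), which did not leave the scatter; the rest of the change has no measured counterpart. No step beyond the scatter is therefore expected in this assay, and the expected step, a 1.1-fold lower number from compound 3 to compound 4 (0.05 log units; within the scatter), is set accordingly. Compound 4 is expected to give about 14000 nM, estimated within 5000 nM to 40000 nM.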

Compound 4, half-maximal inhibitory concentration: 40400 nM
Compound 4: middle estimate off by 2.9-fold (0.46 log units), on the low side; the measured number lies above the stated range.
By their numbers in this assay, from the lowest: compounds 2, 1 and 3 (each within the scatter of the next); then compound 4.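

In this assay, for the compounds shown here, the place of the chloro group on the phenyl ring matters: 4-chlorophenyl in place of 3-chlorophenyl gives a 2.8-fold higher number from compound 1 to compound 4 (0.45 log units; beyond the scatter) and is the first step beyond the scatter at this amide-type nitrogen. Compound 4 also separates from the other two, with a 4.2-fold higher number from compound 2 to compound 4 (0.62 log units; beyond the scatter) and a 2.6-fold higher number from compound 3 to compound 4 (0.41 log units; beyond the scatter) as modest steps, so it is the weakest of the four, whereas the 3-chloro, 3-bromo and 3-ethyl phenyl groups stay within the scatter of each other. Nothing available explains this step.

Open, as far as these compounds go, is whether 4-bromophenyl or 4-ethylphenyl would show the same step. Also open, from the compounds shown here alone, is how an amine or a carboxylic acid on this ring would read.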